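Solubility notes on the azaspiro-to-azabicycle swap in compound 1

The source may hold more compounds than are shown below. What is called first, only, known or untested is meant among the compounds shown, and "the series" means these compounds.

The series shares an amide-linked core and a benzyl-bearing lactam ring; compound 1 `COc1ccc2[nH]c(C(=O)N3CC(=O)N(Cc4ccccc4)[C@@H](CCN4CCC5(CC4)CC5)C3)cc2c1` carries a basic amine on a two-carbon chain from the saturated ring carbon. In a physicochemical assay for solubility, read by spectrophotometry, in phosphate buffer, with a stated time of 2 h, at pH 7.4 (on this read-out lower numbers stand for lower solubility and higher numbers for higher solubility), compound 1 returns only a limit, > 25000 nM, and no number. Of the three values in hand this is the limit of > 25000 nM in this assay, at which 1 of the 3 values shown sits. The two companions give numbers: in this assay compound 2 `O=C(c1cc2cc(C3CC3)ccc2[nH]1)N1CC(=O)N(Cc2ccccc2)[C@@H](CN2CCN(Cc3ccccc3)CC2)C1` gives 12900 nM, and compound 3 `COc1ccc2[nH]c(C(=O)N3CC(=O)N(Cc4ccccc4)[C@@H](N4CCC(Cc5ccccc5)CC4)C3)cc2c1` gives 9300 nM; these two values sit within the scatter of each other, so no order is read between them. Among the measured compounds shown here, no single-point step between measured compounds exists here.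

Compound 4 `COc1ccc2[nH]c(C(=O)N3CC(=O)N(Cc4ccccc4)[C@@H](CN4CC5CC5C4)C3)cc2c1` differs from compound 1 by a group of 6 heavy atoms (5 carbon, 1 nitrogen; one three-membered non-aromatic ring of carbon only, one five-membered non-aromatic ring with 1 hetero atom) in place of a group of 9 heavy atoms (8 carbon, 1 nitrogen; one three-membered non-aromatic ring of carbon only, one six-membered non-aromatic ring with 1 hetero atom), on a saturated chain carbon bound to a saturated ring carbon. Since compound 1 stands at the limit, the step cannot be read from a number; the expectation is no shift beyond the scatter, with compound 4 again likely reported only as a limit. The estimated step is a number no higher from compound 1 to compound 4 (the limit leaves the size open). For compound 4 in this assay the estimate is 25000 nM, within 12000 nM to 50000 nM.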

Compound 4, solubility: 17500 nM
Estimate against measurement, compound 4: 1.4-fold (0.15 log units) above; low and high end bracket the measured number.
By their numbers in this assay, from the lowest: compounds 3, 2 and 4 (each within the scatter of the next). At a limit, above all of these: compound 1.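

Compound 1 holds a limit and not a number: the limit of > 25000 nM in this assay, at which 1 of the 4 values shown sits.

In this assay, the smaller group on a saturated chain carbon bound to a saturated ring carbon gives an at least 1.4-fold lower number from compound 1 to compound 4 (0.15 log units; that floor lies within the scatter), so the step as printed is only a floor and does not by itself separate the two compounds. What is new is a measured value for a group carrying a three-membered carbon ring at this place, since compound 4 gives 17500 nM, a usable reference for further changes here.

As far as these compounds go, the true size of the step stays open, and so does whether it follows from the five-membered ring in place of the six-membered one or from the loss of the three-membered ring's spiro attachment. A morpholine or a plain pyrrolidine at this place would help separate these readings.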